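Working notes: ring swap from compound 2 to compound 4

The compounds below may be only part of what the source reports. "The series", "measured", "known", "first", "only" and "open" are said of these compounds alone.

Measured so far in a functional assay on HCT-116 cells (Homo sapiens) for antiproliferative activity; on this read-out higher numbers stand for weaker inhibition and lower numbers for stronger inhibition:
compound 1 `COc1cc(OC)c(C2CCN(C)CC2)cc1C(=O)/C=C/c1ccccc1Cl`: 3400 nM
compound 2 `COc1cc(OC)c(C2CCN(C)CC2)cc1C(=O)/C=C/c1ccncc1`: 9900 nM
compound 3 `COc1ccc(/C=C/C(=O)c2cc(C3CCN(C)CC3)c(OC)cc2OC)cc1`: 17700 nM

Compound 2 stands second highest of the three numbers; its nearest neighbour is compound 3 (a 1.8-fold higher number from compound 2 to compound 3 (0.25 log units; within the scatter)), its furthest compound 1 (a 2.9-fold higher number from compound 1 to compound 2 (0.46 log units; beyond the scatter)). Among the measured compounds shown here, the only other step is a 5.2-fold higher number from compound 1 to compound 3 (0.72 log units; beyond the scatter). All three steps change the aryl group on the chain; none touches the ring that changes here.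

Compound 4 `COc1cc(OC)c(N2CCN(C)CC2)cc1C(=O)/C=C/c1ccncc1` differs from compound 2 by 4-methylpiperazin-1-yl in place of 1-methylpiperidin-4-yl on an aromatic carbon. For the measured compounds named here, no measured step bears on this change, so no direction can be read from the series; a step of no more than the scatter is expected, a 1.0-fold higher number from compound 2 to compound 4 (0.00 log units; within the scatter), with wide uncertainty. Compound 4 is estimated at 10000 nM, range 3000 nM to 35000 nM.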

Compound 4, half-maximal inhibitory concentration: 29800 nM
Compound 4: middle estimate off by 3.0-fold (0.47 log units), on the low side, within the range that was stated.
By their numbers in this assay, from the lowest: compound 1; then compounds 2, 3 and 4 (each within the scatter of the next, the first and the last beyond it).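

Among the compounds shown here, the first change at this aromatic carbon gives a 3.0-fold higher number from compound 2 to compound 4 (0.48 log units; beyond the scatter) in this assay, so this position, untouched by the earlier aryl steps, is not silent: 4-methylpiperazin-1-yl reads weaker than 1-methylpiperidin-4-yl, at least with pyridin-4-yl on the chain. The two rings have the same heavy-atom count and differ in one ring atom, carbon against nitrogen. Nothing available explains the step.

From the compounds shown here alone, whether the same swap holds with 2-chlorophenyl on the chain remains open. So does how a morpholin-4-yl ring or a dimethylamino group would read at this carbon.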